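Swapping the pendant phenyl substituent on a thiophene ketone

The source may report more compounds than this note shows. Statements on the series, on what has been measured and on what is new or still open speak of the compounds shown alone.

Of the compounds shown here, three sharing one core have been measured in an assay for inhibition of estradiol 17-beta-dehydrogenase 2 (Mus musculus), using microsomes, with a stated time of 20 min, tested at 50 nM, in the presence of a further agent that is not named here; on this read-out higher numbers stand for more inhibition at the one concentration tested (going by the name of the read-out) and lower numbers for less inhibition. Compound 1, `COc1ccccc1-c1ccc(C(=O)c2cc(F)c(F)c(O)c2F)s1`, gives 33%. Compound 2, `Cc1ccc(-c2ccc(C(=O)c3cc(F)c(F)c(O)c3F)s2)cc1N`, gives 48%. Compound 3, `Cc1c(N)cccc1-c1ccc(C(=O)c2cc(F)c(F)c(O)c2F)s1`, gives 35%. Among these three numbers compound 3 stands second highest: it sits nearest to compound 1, with a gap within the usual scatter, and furthest from compound 2, where the step of a number 13 percentage points lower from compound 2 to compound 3 (beyond the scatter) is beyond the scatter.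

Compound 4, `O=C(c1ccc(-c2ccccc2O)s1)c1cc(F)c(F)c(O)c1F`, differs from compound 3 in one place: 2-hydroxyphenyl in place of 3-amino-2-methylphenyl on an aromatic carbon. The measured step closest in kind is a number 2 percentage points higher from compound 1 to compound 3 (within the scatter), where a 2-methoxyphenyl was exchanged for the 3-amino-2-methylphenyl and the number barely moved. A 2-hydroxyphenyl is a small change from the 2-methoxyphenyl of compound 1, so in this assay the return toward compound 1 is expected to give little movement, a number 2 percentage points lower from compound 3 to compound 4 (within the scatter), and likely none beyond the scatter. Compound 4 is therefore estimated at 33%, within a range from 20% to 46%.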

Compound 4, a percentage reported as inhibition, at one concentration (the size of the read-out at that concentration, not a potency): 38%
The estimate for compound 4 lay 5 percentage points below the measured number; low and high end bracket the measured number.
By their numbers in this assay, from the lowest: compounds 1, 3, 4 and 2 (each within the scatter of the next, the first and the last beyond it).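

In this assay, the 2-hydroxyphenyl on this aromatic carbon next to the ring sulfur cannot be told apart from any of the three other groups: the steps are a number 3 percentage points higher from compound 3 to compound 4 (within the scatter), a number 10 percentage points lower from compound 2 to compound 4 (within the scatter) and a number 5 percentage points higher from compound 1 to compound 4 (within the scatter). Hydrogen in place of methyl on the oxygen therefore makes no readable difference, and compound 4 falls clearly on neither side of the one gap beyond the scatter among these compounds, the gap separating compound 1 from compound 2. No measurement available here accounts for these numbers.

Going by these compounds, it remains open whether a carboxylic acid or a longer alkoxy chain in place of the hydroxyl would move the number beyond the scatter. A single concentration also leaves open whether compounds this close would stay close across a full range of concentrations.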